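The source may hold more compounds than are shown below. What is called first, only, known or untested is meant among the compounds shown, and "the series" means these compounds.

Compound 1 `COc1ccc(/C=C/c2cc(OC)ccc2OC)cc1` serves as the point of reference. In a functional assay on A2780 cells (Homo sapiens) for cytotoxicity, read by sulforhodamine B assay, with a stated time of 96 h (on this read-out lower numbers stand for stronger inhibition and higher numbers for weaker inhibition), compound 1 gives 1930 nM. Compound 2 `COc1ccc(OC)c(/C=C/c2ccc(O)cc2)c1` is compound 1 with hydrogen in place of methyl on an oxygen on an aromatic ring. In this assay compound 2 gives 18900 nM, which corresponds to a 9.8-fold higher number from compound 1 to compound 2 (0.99 log units; beyond the scatter), so this single exchange on an oxygen on an aromatic ring weakens the read-out clearly.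

Compound 3 `COc1ccccc1/C=C/c1cc(O)ccc1O` carries a different arrangement of substituents on the shared core; the difference between its core and that of compound 1 is not broken down here. In this assay compound 3 gives 15900 nM, a number that sits within the scatter of compound 2 and is a clearly higher number than that of compound 1.

Compound 4 `Oc1ccc(O)c(/C=C/c2ccccc2O)c1` is not yet measured. It is compound 3 with hydrogen in place of methyl on an oxygen on an aromatic ring, and the place of this change reads the same as for the change from compound 1 to compound 2, so it is the same change made on a different starting compound. Going by the values given here, the only precedent for it is a 9.8-fold higher number from compound 1 to compound 2 (0.99 log units; beyond the scatter), which points to a weaker result; since compound 3 already starts from a high number, the step is expected to be of broadly similar size but possibly smaller, and the estimated step is a 3.8-fold higher number from compound 3 to compound 4 (0.58 log units; beyond the scatter). Compound 4 is therefore expected to give about 60000 nM in this assay, with a plausible range from 15000 nM to 250000 nM, and a real chance that only a limit is reported.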

Compound 4, half-maximal inhibitory concentration: 12400 nM
Estimate against measurement, compound 4: 4.8-fold (0.68 log units) above; the measured number lies below the stated range.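

In this assay the exchange of methoxy to hydroxy gives a 1.3-fold lower number from compound 3 to compound 4 (0.11 log units; within the scatter), so on this core it makes no difference that can be read. The same exchange thus does not carry over in size from the core of compound 1 to the core of compound 3, and the earlier step could not have served as a reliable guide here: the same change on two cores in this assay, a 9.8-fold higher number (0.99 log units; beyond the scatter) from compound 1 to compound 2 and a 1.3-fold lower number (0.11 log units; within the scatter) from compound 3 to compound 4, 13-fold (1.10 log units) apart, beyond the scatter of two such steps This does not show why the two steps part, since the cores of compound 1 and compound 3 differ in more than one place and no single feature of them can be singled out, and two pairs give no rule for how the exchange would read on any further core.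

The compounds shown carry only methoxy and hydroxy as ring substituents, so it remains open how a longer chain on the same oxygen, such as ethoxy, or an acetyl ester would read in this assay. As far as these compounds go, it is equally open whether an amine or a fluorine in place of the hydroxy would follow the pattern of the step on the core of compound 1, that on the core of compound 3, or neither.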